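Adding an ethyl group to the ring nitrogen of compound 2

A few compounds are considered here, and "the series" means these few. Any claim that something is new, unique, unknown or untested is made for them only; others in the source may bear on it.

In a functional assay on K562 cells (Homo sapiens) for antiproliferative activity, read by MTT assay, with a stated time of 72 h (a lower number here means a stronger inhibitor, a higher number a weaker inhibitor), three compounds have been measured so far. Compound 1 `O=C1NC(=O)/C(=C/C2=Cc3cc(Br)ccc3OC2)S1` gives 49800 nM. Compound 2 `CC1Oc2ccc(Br)cc2C=C1/C=C1\SC(=O)NC1=O`, which carries a methyl group on a saturated ring carbon, gives 77000 nM; the change a 1.5-fold higher number from compound 1 to compound 2 (0.19 log units; within the scatter) lies within the scatter, so these two compounds cannot be told apart. Compound 3 `CC1Oc2ccc(Br)cc2C=C1/C=C1\NC(=O)NC1=O` gives 10600 nM, a clearly lower number than compound 2, so compound 2 holds the highest number of the three, though it shares that position with compound 1 within the scatter.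

Compound 4 `CCN1C(=O)S/C(=C\C2=Cc3cc(Br)ccc3OC2C)C1=O` is not yet measured. It differs from compound 2 in one place: ethyl in place of hydrogen on an amide-type nitrogen in a ring. Among the measured compounds shown here, no measured step touches this position. For the measured compounds named here, the one step that is known, from compound 1 to compound 2, concerns a different ring atom and was within the scatter. The gap between compound 2 and compound 3 involves a different exchange and says nothing about an ethyl on the nitrogen.

Going by the values given here, with no step that bears on this change, the expectation for compound 4 is a number close to that of compound 2, with wide uncertainty, so the estimated step of a 1.0-fold higher number from compound 2 to compound 4 (0.02 log units; within the scatter) stays within the scatter. The estimate for compound 4 is 80000 nM, between 30000 nM and 200000 nM.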

Compound 4, half-maximal inhibitory concentration: > 100000 nM
Compound 4: only a limit was reported; the forecaster's own chance of this, stated with the estimate: 25%; middle value at least 1.2-fold (0.09 log units) from the limit.
By their numbers in this assay, from the lowest: compound 3; then compounds 1 and 2 (each within the scatter of the next). At a limit, above all of these: compound 4.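

In this assay compound 4 gives > 100000 nM, which is a limit of the assay and not a number. Among the compounds shown, only compound 4 changes the amide-type nitrogen in the ring, and ethyl in place of hydrogen there brings no lowering of the number, the result being an at least 1.2-fold higher number from compound 2 to compound 4 (0.11 log units; that floor lies within the scatter). Only a floor for this step is known, so the true step could lie within the scatter or far beyond it, because the reading ends at a limit: the limit of > 100000 nM in this assay, at which 1 of the 4 values shown sits.

The compounds shown leave open whether this nitrogen accepts any other group without a rise in the number, such as a methyl group, a longer chain like propyl, or a short chain ending in an amine or a carboxylic acid. A single ethyl group also cannot show whether the outcome depends on removing the amide hydrogen or on the particular group that replaces it, and a smaller or a differently built group on the same nitrogen would be needed to separate the two.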